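Working notes: amide to sulfonamide, compounds 1 to 4

This account rests on a few compounds, and the source may have more. Where it says the series, first, only, none or still open, it means among the compounds named here.

Measured so far:
compound 1, `O=C(Nc1cccc(/C=C/C(=O)c2nc3ccccc3[nH]2)c1)c1ccc(Cl)cc1`: 8410 nM
compound 2, `O=C(Nc1cccc(/C=C/C(=O)c2nc3ccccc3[nH]2)c1)c1ccc(Br)cc1`: 7000 nM
compound 3, `O=C(Nc1cccc(/C=C/C(=O)c2nc3ccccc3[nH]2)c1)c1cc(Cl)cc(Cl)c1`: > 100000 nM

All three share one core and differ only in the group carried on the nitrogen on the aromatic ring. In a functional assay on MCF7 cells (Homo sapiens) for antiproliferative activity, read by MTT assay, with a stated time of 48 h (on this read-out higher numbers stand for weaker inhibition and lower numbers for stronger inhibition), compound 1 gives 8410 nM and compound 2 gives 7000 nM; the step of a 1.2-fold lower number from compound 1 to compound 2 (0.08 log units; within the scatter), so the two halogens are not told apart here. For compound 3 the result is only a limit of this assay, > 100000 nM, the point described as the limit of > 100000 nM in this assay, at which 1 of the 3 values shown sits. Compound 3 thus stands at the weak end of what has been measured: the steps of an at least 11-fold higher number from compound 1 to compound 3 (1.07 log units; beyond the scatter) and an at least 14-fold higher number from compound 2 to compound 3 (1.15 log units; beyond the scatter) are both large and both run toward weaker inhibition.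

Compound 4, `O=C(/C=C/c1cccc(NS(=O)(=O)c2ccc(Cl)cc2)c1)c1nc2ccccc2[nH]1`, is not yet measured. Its change from compound 3 is (4-chlorophenyl)sulfonyl in place of (3,5-dichlorophenyl)carbonyl on a nitrogen on an aromatic ring. Among the compounds with values here, no measured step covers a carbonyl-to-sulfonyl exchange, so that part of the change is open. The halogen pattern, however, returns to that of compound 1, which gives 8410 nM, and the two large steps into compound 3 suggest the move back out should be of similar size in the opposite direction. The expected step is an at least 6.6-fold lower number from compound 3 to compound 4 (0.82 log units; beyond the scatter). Compound 4 is therefore estimated at about 15000 nM, within 4000 nM to 80000 nM.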

Compound 4, half-maximal inhibitory concentration: 3820 nM
Beside the measured number, compound 4's estimate is 3.9-fold (0.59 log units) above it; measured number outside the range, below it.
By their numbers in this assay, from the lowest: compounds 4, 2 and 1 (each within the scatter of the next, the first and the last beyond it). At a limit, above all of these: compound 3.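

The carbonyl-to-sulfonyl exchange can now be read directly with the 4-chlorophenyl group held constant: in this assay, it gives a 2.2-fold lower number from compound 1 to compound 4 (0.34 log units; beyond the scatter), a modest step toward stronger inhibition, so on this nitrogen on an aromatic ring the sulfonyl linkage does not cost activity. Set against the bromo amide, the same kind of change gives a 1.8-fold lower number from compound 2 to compound 4 (0.26 log units; within the scatter), which leaves compound 2 and compound 4 not told apart and keeps the gain over the amides small. Compound 3 remains a limit of this assay, and the step out of it reads an at least 26-fold lower number from compound 3 to compound 4 (1.41 log units; beyond the scatter), so the large separation seen with the 3,5-dichlorophenyl amide persists with the sulfonyl in place: the limit of > 100000 nM in this assay, at which 1 of the 4 values shown sits.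

As far as these compounds go, whether the 3,5-dichlorophenyl pattern is equally poor on the sulfonyl remains open, as does whether (4-bromophenyl)sulfonyl would match compound 4. From the compounds shown here alone, it is also open whether an aromatic ring is needed on the sulfonyl at all, for example whether a methyl group there, or a urea in place of the linkage, would hold this level of inhibition.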